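Acetyl in place of a silicon group on compound 1's core

The source may hold more compounds than are shown below. What is called first, only, known or untested is meant among the compounds shown, and "the series" means these compounds.

Compound 1 `COc1ccc(C2=C(c3cc(OC)c(OC)c(OC)c3)C(=O)C(O[SiH2]C(C)(C)C)C2)cc1OC(C)C` — 9 ug/mL in an ADME assay on HT-29 cells (Homo sapiens) for cytotoxicity, read by MTT assay, with a stated time of 72 h; on this read-out higher numbers stand for weaker inhibition and lower numbers for stronger inhibition
Compound 2 `COC(=O)c1cc(C2=C(c3cc(OC)c(OC)c(OC)c3)C(=O)CC2O[SiH2]C(C)(C)C)ccc1OC` — a limit of the assay, > 100 ug/mL

In this assay, among the measured compounds shown here, compound 1 carries the only number given; the other value is a limit. Compound 2 sits at the limit of > 100 ug/mL in this assay, at which 1 of the 2 values shown sits, and its result is a limit rather than a number. For the measured compounds named here, no pair of measured compounds differs in a single place, so no measured step is at hand to calibrate how a change on the shared core moves the read-out.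

Compound 3 `COc1ccc(C2=C(c3cc(OC)c(OC)c(OC)c3)C(=O)C(OC(C)=O)C2)cc1OC(C)C` is the next compound to be measured in this assay. It differs from compound 1 by a group of 3 heavy atoms (2 carbon, 1 oxygen; no ring) in place of a group of 5 heavy atoms (4 carbon, 1 silicon; no ring), on an oxygen on a saturated carbon. Going by the values given here, with no measured step to lean on, the expectation rests on the numerical value of compound 1 alone, 9 ug/mL, and on the modest size of the exchange. Compound 3 is expected to give about 12 ug/mL in this assay, within a range from 4 ug/mL to 40 ug/mL, which means an expected step of a 1.3-fold higher number from compound 1 to compound 3 (0.12 log units; within the scatter) toward slightly weaker inhibition, not clearly beyond the scatter.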

Compound 3, half-maximal inhibitory concentration: > 100 ug/mL
Compound 3 was reported as a limit; the forecaster's own chance of this, stated with the estimate: 10%; at least 8.3-fold (0.92 log units) between middle value and limit.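

Among the compounds shown here, replacing the silicon group with acetyl on the oxygen on a saturated carbon gives the first measured step on the core of compound 1: in this assay, the exchange produces an at least 11-fold higher number from compound 1 to compound 3 (1.04 log units; beyond the scatter). This shows that the read-out at this position depends strongly on the group carried by the oxygen, and that the shared core with an acetyl there does not keep the inhibition seen for compound 1. The result for compound 3 is a limit of the assay, and limits now make up most of the results shown: the limit of > 100 ug/mL in this assay, at which 2 of the 3 values shown sit.

The compounds shown give no cause for the step and cannot separate the role of the silicon atom from that of the other atoms in the group that leaves. From the compounds shown here alone, it remains open whether a free hydroxyl, a methyl ether or a longer ester such as butanoyl on the same oxygen would stay close to compound 1 or fall away as acetyl does.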